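Pyridin-2-yl for hydroxy on the amide-type nitrogen

The source may report more compounds than this note shows. Statements on the series, on what has been measured and on what is new or still open speak of the compounds shown alone.

Working notes on the series. In a functional assay on KB cells (Homo sapiens) for inhibition, read by MTT assay, with a stated time of 24 h, tested at 1 ug/mL (a higher number here means more inhibition of growth at the concentration tested, a lower number less inhibition of growth), compound 2 `O=C(CCCCC1CCSS1)NO` gives 2.57%, within the scatter of compound 1 `CC(=O)SCCC(CCCCC(=O)O)SC(C)=O` at 12.4%. Compound 3 `O=C(CCCCC1CCSS1)Nc1ccc([N+](=O)[O-])c(C(F)(F)F)c1` is reported as "not active" (no number reported), with no number attached, so compound 2 cannot be placed against it numerically.

Compound 4 `O=C(CCCCC1CCSS1)Nc1ccccn1` carries pyridin-2-yl in place of the hydroxy of compound 2 on the amide-type nitrogen (pyridin-2-yl in place of hydroxy on an amide-type nitrogen). Among the measured compounds shown here, no measured pair differs in one place, so this change has no direct precedent here.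

A change beyond the scatter in this assay is not expected in either direction. This expectation rests on compound 2 at 2.57% and on compound 3 at "not active" (no number reported), whose amide-type nitrogen also carries an aromatic ring. The estimated step of a number 3.4 percentage points higher from compound 2 to compound 4 (within the scatter) stays within the scatter. A result reported without a number would also fit these data. Compound 4 is expected at 6%, with an estimated range from 0% to 18%.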

Compound 4, percent growth inhibition at one concentration: "not active" (no number reported)
The entry for compound 4 holds no number; the estimate stays without a comparison.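

In this assay, among the compounds shown here, compound 4 stands as "not active" (no number reported), and no step from compound 2 to compound 4 can be read. The compounds shown leave open whether pyridin-2-yl in place of hydroxy on the amide-type nitrogen shifts growth inhibition at all. Nothing available bears on this result.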